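The source may report more compounds than this note shows. Statements on the series, on what has been measured and on what is new or still open speak of the compounds shown alone.

Measured compounds:
Compound 1 `COc1cc(F)c(NC(=O)c2ccncc2)cc1Nc1nccc(-c2cn(C)c3ccccc23)n1` gives 4200 nM in a functional assay on A549 cells (Homo sapiens) for antiproliferative activity, read by MTT assay, with a stated time of 72 h; a higher number here means a weaker inhibitor, a lower number a stronger inhibitor.
Compound 2 `COc1cc(N(C)CCN(C)C)c(NC(=O)c2ccncc2)cc1Nc1nccc(-c2cn(C)c3ccccc23)n1` gives 10400 nM in this assay.
Compound 3 `COc1cc(N(C)CCN(C)C)c(NC(=O)c2cnccn2)cc1Nc1nccc(-c2cn(C)c3ccccc23)n1` gives 4330 nM in this assay.

Compound 2 stands at the highest of the three numbers in this assay: compound 3 sits nearest, with a 2.4-fold lower number from compound 2 to compound 3 (0.38 log units; beyond the scatter), and compound 1 sits furthest, the reverse of a 2.5-fold higher number from compound 1 to compound 2 (0.39 log units; beyond the scatter). Compound 4 `COc1cc(N(C)C)c(NC(=O)c2ccncc2)cc1Nc1nccc(-c2cn(C)c3ccccc23)n1` differs from compound 2 by hydrogen in place of (dimethylamino)methyl on a saturated chain carbon bound to a nitrogen on an aromatic ring. For the measured compounds named here, one measured step bears on this change: the step from compound 1 to compound 2, which put the whole (2-(dimethylamino)ethyl)(methyl)amino group in place of fluoro and gave a 2.5-fold higher number from compound 1 to compound 2 (0.39 log units; beyond the scatter). Compound 4 removes part of that group again, so some of that rise is expected to be undone; the step from compound 2 to compound 3 touches a different place and is no guide here. A modest lower number, a 1.7-fold lower number from compound 2 to compound 4 (0.24 log units; within the scatter), is therefore expected for compound 4 in this assay. Compound 4 is estimated at 6000 nM, within a range of 2500 nM to 15000 nM.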

Compound 4, half-maximal inhibitory concentration: 9000 nM
Estimate against measurement, compound 4: 1.5-fold (0.18 log units) below, within the range that was stated.
By their numbers in this assay, from the lowest: compounds 1 and 3 (each within the scatter of the next); then compounds 4 and 2 (each within the scatter of the next).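

Removing (dimethylamino)methyl from the saturated chain carbon gives a pair that cannot be told apart in this assay, with a 1.2-fold lower number from compound 2 to compound 4 (0.06 log units; within the scatter). Dimethylamino in place of fluoro on the aromatic carbon already gives a 2.1-fold higher number from compound 1 to compound 4 (0.33 log units; beyond the scatter), close in size to the earlier 2.5-fold higher number from compound 1 to compound 2 (0.39 log units; beyond the scatter). Among these compounds, then, the step away from fluoro does not depend on the (dimethylamino)methyl portion, and nothing shown here explains that result.

As far as these compounds go, it remains open whether a morpholine ring or a longer chain on this aromatic carbon would fit the same picture. From the compounds shown here alone, it is also open whether pyrazin-2-yl in place of pyridin-4-yl would shift the number with dimethylamino present, as it did with the larger group in compound 3.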